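Back from Urea to Amide: What to Expect of Compound 3

A few compounds are considered here, and "the series" means these few. Any claim that something is new, unique, unknown or untested is made for them only; others in the source may bear on it.

Measured compounds:
compound 1 `COc1cc(-c2nn(-c3cccc(NC(=O)c4cccc(C(F)(F)F)c4)c3)cc2-c2ccncc2)ccc1Cl` — in a functional assay on OVCAR-5 cells (Homo sapiens) for inhibition, read by sulforhodamine B assay, with a stated time of 48 h (on this read-out higher numbers stand for weaker inhibition of growth and lower numbers for stronger inhibition of growth), compound 1 gives > 50000 nM, which is a limit of the assay rather than a number.
compound 2 `COc1cc(-c2nn(-c3cccc(NC(=O)Nc4cccc(C(F)(F)F)c4)c3)cc2-c2ccncc2)ccc1Cl` — in this assay compound 2 gives 6450 nM.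

Among the compounds with values here, compound 2 thus holds the only number in this assay; the one other value is a limit (the limit of > 50000 nM in this assay, at which 1 of the 2 values shown sits). Compound 3 `COc1cc(-c2nn(-c3cccc(NC(=O)c4ccc(Cl)c(C(F)(F)F)c4)c3)cc2-c2ccncc2)ccc1Cl` differs from compound 2 by 4-chloro-3-(trifluoromethyl)phenyl in place of (3-(trifluoromethyl)phenyl)amino on a carbonyl carbon. Within the data shown here, one measured step bears on this change, and it ran the other way: an at least 7.7-fold lower number from compound 1 to compound 2 (0.88 log units; beyond the scatter), a move from an aryl carbonyl amide to the urea. Compound 3 turns the carbonyl substituent back into an aryl group, now carrying the chloro substituent named in the entering group, for which no step is shown. A step of roughly the same size, in the weakening direction, is therefore expected, a 6.2-fold higher number from compound 2 to compound 3 (0.79 log units; beyond the scatter), with a real chance that compound 3 again reaches only the limit. Compound 3 is estimated at 40000 nM, within 12000 nM to 150000 nM.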

Compound 3, concentration for total growth inhibition: > 32500 nM
Compound 3: a limit, no number; the forecaster's own chance of this, stated with the estimate: 55%; the middle value does not contradict the limit.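

In this assay the change from (3-(trifluoromethyl)phenyl)amino to 4-chloro-3-(trifluoromethyl)phenyl on the carbonyl carbon gives an at least 5.0-fold higher number from compound 2 to compound 3 (0.70 log units; beyond the scatter) and so shows that the loss on leaving the urea recurs with a second aryl group, this one carrying a chloro. Compound 3 gives > 32500 nM and this is a limit of the assay, not a number. Of the three compounds, only the urea, compound 2, reaches a number, and the step from compound 1 to compound 3 cannot be read, both values being limits.

As far as these compounds go, whether the chloro changes growth inhibition at all therefore stays open, on the amide and on the urea alike. Also open, from the compounds shown here alone, is whether the amino nitrogen on the carbonyl carbon could give way to an oxygen, as in a carbamate, or to a methylene, and still yield a number.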